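A few compounds are considered here, and "the series" means these few. Any claim that something is new, unique, unknown or untested is made for them only; others in the source may bear on it.

Measured in a functional assay on MGC-803 cells (Homo sapiens) for inhibition, read by CCK-8 assay, with a stated time of 48 h; a higher number here means a weaker inhibitor, a lower number a stronger inhibitor:
- compound 1 `COc1ccc(CN(C(=O)CSC(=S)N2CCN(C)CC2)c2cc(OC)c(OC)c(OC)c2)cc1`: 1280 nM
- compound 2 `CCN1CCN(C(=S)SCC(=O)N(Cc2ccc(OC)cc2)c2cc(OC)c(OC)c(OC)c2)CC1`: 9890 nM

Compound 2 has the higher number of the two, which makes it the weaker inhibitor. Compound 3 `COc1ccc(CN(C(=O)CSC(=S)N2CCN(C(C)=O)CC2)c2cc(OC)c(OC)c(OC)c2)cc1` changes the group on the same ring nitrogen: acetyl in place of ethyl on an amine nitrogen in a ring. Among the measured compounds shown here, only one measured step bears on this, a 7.7-fold higher number from compound 1 to compound 2 (0.89 log units; beyond the scatter), which is modest but beyond the scatter. It involves no acetyl, so it offers only a rough guide to size. In this assay a modest fall in the number is expected, a 2.0-fold lower number from compound 2 to compound 3 (0.30 log units; within the scatter). The estimated value for compound 3 is 5000 nM, with an expected range of 1200 nM to 20000 nM.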

Compound 3, half-maximal inhibitory concentration: 480 nM
Beside the measured number, compound 3's estimate is 10-fold (1.02 log units) above it, outside the stated range (below it).
By their numbers in this assay, from the lowest: compound 3; then compound 1; then compound 2.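

In this assay the swap of ethyl for acetyl on the ring nitrogen gives a 21-fold lower number from compound 2 to compound 3 (1.31 log units; beyond the scatter) and is the largest step seen so far. With a 2.7-fold lower number from compound 1 to compound 3 (0.43 log units; beyond the scatter) acetyl also outdoes methyl, so the groups on this nitrogen rank acetyl, then methyl, then ethyl. No measurement at hand explains why acetyl does best. From the compounds shown here alone, whether the gain belongs to acetyl alone or to any carbonyl on this nitrogen stays open: a longer acyl chain or a carbamate would test that. How a bare ring amine hydrogen would compare is also unknown.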